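The source may hold more compounds than are shown below. What is called first, only, known or untested is meant among the compounds shown, and "the series" means these compounds.

Compound 1 `COc1ccc(-c2cnc(NC(=O)c3ccco3)n2C)cc1` gives in a toxicity assay on THP-1 cells (Homo sapiens) for inhibition (a higher number here means that more compound is tolerated, a lower number that less compound is tolerated), only a limit, namely > 100000 nM. Compound 2 `COc1ccc2c(c1)nc(NC(=O)c1ccc(F)cc1)n2C` likewise gives only a limit in this assay, namely > 100000 nM. Both values sit at the limit of > 100000 nM in this assay, at which 2 of the 2 values shown sit, so no measured step exists within the pair and compound 1 stands at the tolerated ceiling of the numbers shown. Compound 3 `COc1ccc(-c2cnc(NC(=O)c3ccccc3O)n2C)cc1` carries the change (2-hydroxyphenyl in place of furan-2-yl on a carbonyl carbon). Among the measured compounds shown here, no measured step for such a change is available, so the step of a number no higher from compound 1 to compound 3 (the limit leaves the size open) is expected to be none beyond the scatter. Compound 3 is therefore estimated at 100000 nM in this assay, with a range from 30000 nM to 300000 nM, most probably reported again as a limit.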

Compound 3, half-maximal cytotoxic concentration: > 100000 nM
Compound 3: no number, only a limit; the forecaster's own chance of this, stated with the estimate: 85%; the middle value lies on the limit itself.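

Among the compounds shown here, no step from compound 1 to compound 3 can be read, as both values are limits: the limit of > 100000 nM in this assay, at which 3 of the 3 values shown sit.

In this assay the compounds shown leave open where toxicity begins for any of them, and whether 2-hydroxyphenyl and furan-2-yl differ at all.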